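The source may hold more compounds than are shown below. What is called first, only, known or untested is meant among the compounds shown, and "the series" means these compounds.

The study measured how much of each compound is tolerated in an ADME assay on MT4 cells (Homo sapiens) for cytotoxicity, read by MTT assay, with a stated time of 96 h; a higher number here means that more compound is tolerated, a lower number that less compound is tolerated. Compound 1 `CCC(=O)Nc1ccc(-c2nc3cc(C(F)(F)F)ccc3n2C2CCCCC2)cc1` gives 17000 nM in this assay, and compound 2 `COc1ccc(-c2nc3cc(C(F)(F)F)ccc3[nH]2)c(OC)c1OC` gives 93000 nM. Compound 3 `Cn1c(-c2ccc([N+](=O)[O-])cc2)nc2cc(C(F)(F)F)ccc21` is the third member of the set. For compound 3, this assay reports only the limit >= 100000 nM and no number. Compound 3 thus sits at the limit of >= 100000 nM in this assay, at which 1 of the 3 values shown sits, the top of the values shown, with the other two compounds giving numbers beneath it. Compound 4 `Cn1c(-c2ccc(NC(=O)CN3CCCC3)cc2)nc2cc(C(F)(F)F)ccc21` has not yet been measured. It is related to compound 3 by one change: (((pyrrolidin-1-yl)methyl)carbonyl)amino in place of nitro on an aromatic carbon. For compound 4 in this assay a step downward is expected, an at least 2.0-fold lower number from compound 3 to compound 4 (0.30 log units; that floor lies within the scatter), somewhat beyond the usual scatter, although the starting point is only a limit and the true size of the step cannot be fixed. Compound 4 is estimated to give 50000 nM in this assay, with a range from 15000 nM to 100000 nM, so a number rather than a limit is expected, though a limit remains possible.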

Compound 4, half-maximal cytotoxic concentration: 16000 nM
For compound 4 the middle estimate is 3.1-fold (0.49 log units) above the measured one; the range from low to high includes it.
By their numbers in this assay, from the lowest: compounds 4 and 1 (each within the scatter of the next); then compound 2. At a limit, above all of these: compound 3.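

In this assay, within the data shown here, the earlier compounds offered no pair differing in one place, so this is the first reading of a single change, on an aromatic carbon para to a large group. Placing (((pyrrolidin-1-yl)methyl)carbonyl)amino there instead of nitro gives an at least 6.2-fold lower number from compound 3 to compound 4 (0.79 log units; beyond the scatter), which shows that the number in this assay responds to what this position carries. Compound 3 stands at a limit and not at a number, so the step has only a floor and its true size stays unknown: the limit of >= 100000 nM in this assay, at which 1 of the 4 values shown sits.

Which part of the entering group goes with the step remains open: an acetylamino group, or a dimethylamino group in place of the pyrrolidine ring, would separate the amide from the ring. Also open, from the compounds shown here alone, is how a carboxylic acid or a longer chain at this position would read.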